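Carbonyl substituent series: the step from compound 1 to compound 4

A few compounds are considered here, and "the series" means these few. Any claim that something is new, unique, unknown or untested is made for them only; others in the source may bear on it.

Measured so far:
compound 1 `CC(C)Cc1cc(-c2cccc(Cn3ccnc3)c2)c(S(=O)(=O)NC(=O)OC(C)C)s1` — 160 nM
compound 2 `CCN(CC)C(=O)NS(=O)(=O)c1sc(CC(C)C)cc1-c1cccc(Cn2ccnc2)c1` — 2300 nM
compound 3 `CC(C)Cc1cc(-c2cccc(Cn3ccnc3)c2)c(S(=O)(=O)NC(=O)C2CC2)s1` — 340 nM
compound 4 `CCCC(=O)NS(=O)(=O)c1sc(CC(C)C)cc1-c1cccc(Cn2ccnc2)c1` — not yet measured

In an assay on HEK293 cells for displacement of a labelled ligand from Type-2 angiotensin II receptor (Homo sapiens), read by scintillation counting, with a stated time of 240 min (on this read-out lower numbers stand for stronger inhibition and higher numbers for weaker inhibition), compound 1 gives 160 nM, the lowest of the three numbers. Compound 3 gives 340 nM, and compound 2 gives 2300 nM. The two steps away from compound 1 both sit on the same carbonyl carbon: a 14-fold higher number from compound 1 to compound 2 (1.16 log units; beyond the scatter) and a 2.1-fold higher number from compound 1 to compound 3 (0.33 log units; beyond the scatter). Between the other two, a 6.8-fold lower number from compound 2 to compound 3 (0.83 log units; beyond the scatter).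

Compound 4 differs from compound 1 in one place: propyl in place of isopropoxy on a carbonyl carbon. As in compound 3, a carbon group replaces the isopropoxy on the carbonyl carbon, so the step of a 2.1-fold higher number from compound 1 to compound 3 (0.33 log units; beyond the scatter) is the closest guide, and a modest rise in this assay is expected. Compound 4 is therefore estimated at 350 nM, with a range of 150 nM to 900 nM, which would mean a 2.2-fold higher number from compound 1 to compound 4 (0.34 log units; beyond the scatter).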

Compound 4, inhibition constant: 300 nM
Compound 4: the middle estimate sits 1.2-fold (0.07 log units) above what was measured, and the stated range covers the measured number.
By their numbers in this assay, from the lowest: compounds 1, 4 and 3 (each within the scatter of the next, the first and the last beyond it); then compound 2.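

Propyl on the carbonyl carbon stands within the scatter of isopropoxy (a 1.9-fold higher number from compound 1 to compound 4 (0.27 log units; within the scatter)) and of cyclopropyl (a 1.1-fold lower number from compound 3 to compound 4 (0.05 log units; within the scatter)), so neither the oxygen of isopropoxy nor a ring is needed to stay in this range. Diethylamino remains apart (a 7.7-fold lower number from compound 2 to compound 4 (0.88 log units; beyond the scatter)), which confines the high number to that group among these four.

From the compounds shown here alone, whether a longer chain such as hexyl, a phenyl ring or a smaller amine such as ethylamino on this carbonyl carbon stays in the same range remains open. No measurement shown explains these steps.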